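Adding a Methyl to the Phenyl of Compound 3

A few compounds are considered here, and "the series" means these few. Any claim that something is new, unique, unknown or untested is made for them only; others in the source may bear on it.

Compound 3 `CC(C)(C)c1cc(NC(=O)Nc2cc(F)cc(F)c2)n(-c2ccccc2)n1` stands highest of the three compounds measured in an assay on isolated protein for inhibition of Ephrin type-A receptor 2 (Homo sapiens), read by thermal shift assay, tested at 10 uM (a higher number here means that the compound stabilises the target more against heat, a lower number that the compound stabilises the target less), where compound 3 gives 2.7 degrees C. Compound 1 `Cc1ccccc1NC(=O)Nc1cc(C(C)(C)C)nn1-c1ccccc1` gives 1.2 degrees C, and compound 2 `CC(C)(C)c1cc(NC(=O)Nc2ccc(F)cc2)n(-c2ccccc2)n1` gives -2.2 degrees C. Every measured step changed the aryl group on the amide-type nitrogen: a number 3.4 degrees C lower from compound 1 to compound 2 (beyond the scatter), a number 1.5 degrees C higher from compound 1 to compound 3 (beyond the scatter) and a number 4.9 degrees C higher from compound 2 to compound 3 (beyond the scatter). Compound 4 `Cc1ccc(-n2nc(C(C)(C)C)cc2NC(=O)Nc2cc(F)cc(F)c2)cc1` differs from compound 3 in a different part of the molecule: methyl in place of hydrogen on an aromatic carbon. For the measured compounds named here, no measured step touches this phenyl ring, so nothing in the set bears directly on the change, and a step within the scatter is expected. For compound 4 the estimated value is 2.7 degrees C, with a range from 1.2 degrees C to 4.2 degrees C. The step expected is therefore no change at the digits printed from compound 3 to compound 4 (within the scatter), essentially none beyond the scatter.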

Compound 4, shift of the target's melting temperature: 1.9 degrees C
Estimate against measurement, compound 4: 0.80 degrees C above; the measured number falls inside the stated range.
By their numbers in this assay, from the lowest: compound 2; then compounds 1, 4 and 3 (each within the scatter of the next, the first and the last beyond it).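

Phenyl to 4-methylphenyl is the first change shown on this ring, and in this assay it gives a number 0.80 degrees C lower from compound 3 to compound 4 (within the scatter) and so stays within the scatter. One added methyl at this place therefore moves the number less clearly than the aryl swaps on the amide-type nitrogen, each of which went beyond the scatter. No measurement available here offers a reason for this. On these data alone, whether an amine, a carboxylic acid or a longer chain at this same place would also stay within the scatter remains open.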